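Swapping Nitro for Amino: What Two Numbers Can Say

A few compounds are considered here, and "the series" means these few. Any claim that something is new, unique, unknown or untested is made for them only; others in the source may bear on it.

Among the measured compounds shown here, only two compounds have been measured so far in a functional assay on MC-38 cells (Mus musculus) for antiproliferative activity, read by colorimetric assay and MTT assay; on this read-out lower numbers stand for stronger inhibition and higher numbers for weaker inhibition. For the measured compounds named here, compound 1 (`O=S(=O)(Nc1cccc2cc[nH]c12)c1ccc(Cl)cc1`) gives 7 ug/mL and compound 2 (`O=[N+]([O-])c1ccc(S(=O)(=O)Nc2cccc3cc[nH]c23)cc1`) gives 7.2 ug/mL, so compound 2 stands level with its only neighbour, within the usual scatter of repeated measurements.

The next compound, compound 3 (`Nc1ccc(S(=O)(=O)Nc2cccc3cc[nH]c23)cc1`), keeps the shared core but carries amino in place of nitro on an aromatic carbon, para to a large group: amino in place of nitro on an aromatic carbon.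

Going by the values given here, the only measured step that bears on this change is a 1.0-fold higher number from compound 1 to compound 2 (0.01 log units; within the scatter), where nitro took the place of chloro and the number stayed within the scatter. Among the compounds with values here, that step is indirect evidence, since amino has not yet been measured on this core and no measured step shows what it does. Within the data shown here, the one swap on record gives no reason to expect a large move in this assay, so the expected step is a 1.1-fold higher number from compound 2 to compound 3 (0.05 log units; within the scatter), which is no step beyond the scatter, and its direction stays open. For compound 3 the expected value is 8 ug/mL, with an estimated range from 3 ug/mL to 20 ug/mL.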

Compound 3, half-maximal inhibitory concentration: 6.1 ug/mL
For compound 3 the middle estimate is 1.3-fold (0.12 log units) above the measured one; the measured number falls inside the stated range.
By their numbers in this assay, from the lowest: compounds 3, 1 and 2 (each within the scatter of the next).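

In this assay, amino in place of nitro on this aromatic carbon, para to a large group, gives a 1.2-fold lower number from compound 2 to compound 3 (0.07 log units; within the scatter) and stays level with chloro as well, with a 1.1-fold lower number from compound 1 to compound 3 (0.06 log units; within the scatter) on record for that swap. The earlier pair showed only that nitro and chloro read alike here, and amino now joins them. The swap is not a small one on paper. Nitro, with 3 heavy atoms and 0 hydrogen-bond donors, gives way to amino, with 1 heavy atom and 1 hydrogen-bond donor, and still the number stays within the scatter. No outside evidence bears on this result, so the data offer no explanation for it.

With only chloro, nitro and amino on view, this position looks tolerant for these three groups alone, and a carboxylic acid, a methoxy group or a longer chain at the same place could read differently. The compounds shown also say nothing about changes elsewhere on the shared core, so it remains open whether any change to this series can move the number beyond the scatter.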